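The source may hold more compounds than are shown below. What is called first, only, known or untested is meant among the compounds shown, and "the series" means these compounds.

Working notes on a small set of chalcone-type thioether and sulfone analogues tested in a functional assay on DU-145 cells (Homo sapiens) for inhibition, read by trypan blue exclusion, with a stated time of 96 h; a lower number here means a stronger inhibitor of growth, a higher number a weaker inhibitor of growth.

Compound 1 `Cc1ccc(CS/C(=C/c2ccc(O)c(O)c2O)C(=O)c2ccc(Cl)cc2)cc1` gives 50000 nM in this assay, the highest number of the three measured. Compound 2 `O=C(/C(=C\c1ccc(Cl)cc1)S(=O)(=O)c1ccc(Cl)cc1)c1ccc(Cl)cc1` gives 25000 nM, which lies within the scatter of compound 1, so no order can be claimed between the two. Compound 3 `COc1cc(OC)c(/C=C(\C(=O)c2ccc([N+](=O)[O-])cc2)S(=O)(=O)Cc2ccc(Cl)cc2)c(OC)c1` gives 10000 nM, beyond the scatter and a lower number than compound 1. Among the measured compounds shown here, no pair of these three differs in only one place, so none of the gaps can be tied to a single structural change.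

Compound 4 `Cc1ccc(CS/C(=C/c2cccc(Cl)c2Cl)C(=O)c2ccc(Cl)cc2)cc1` has not been measured. It differs from compound 1 in one place: 2,3-dichlorophenyl in place of 2,3,4-trihydroxyphenyl on a double-bonded chain carbon bound to a double-bonded chain carbon. For the measured compounds named here, nothing among the measured compounds isolates the effect of this exchange. Compound 2 carries a chlorophenyl in the corresponding region and is within the scatter of compound 1, which gives no basis to expect a large move. A step of about a 1.7-fold lower number from compound 1 to compound 4 (0.22 log units; within the scatter) is expected, either within the scatter or a modest shift toward a lower number. Compound 4 is estimated at 30000 nM in this assay, with a range from 8000 nM to 100000 nM.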

Compound 4, concentration for 50% growth inhibition: 25000 nM
Compound 4: the middle estimate sits 1.2-fold (0.08 log units) above what was measured, and the stated range covers the measured number.
By their numbers in this assay, from the lowest: compound 3; then compounds 2, 4 and 1 (each within the scatter of the next).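

In this assay, among the compounds shown here, the exchange of 2,3,4-trihydroxyphenyl for 2,3-dichlorophenyl on a double-bonded chain carbon bound to a double-bonded chain carbon gives a 2.0-fold lower number from compound 1 to compound 4 (0.30 log units; within the scatter), the first step that can be tied to a single place. The group that leaves has 3 hydrogen-bond donors and 3 hydrogen-bond acceptors and the group that enters has 0 of each, yet the two numbers remain within the scatter of each other, so this exchange at this position shows no measurable effect on growth inhibition. No measurement at hand bears on the reason for this result.

On these data alone, both groups compared here are substituted phenyl rings, so it remains open whether an aminomethyl group or a carboxylic acid at the same place would give a number beyond the scatter of compound 1. The lower number of compound 3 also remains unconnected to any single structural change, since no compound shown differs from it in only one place.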